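Methyl on one hydroxy of compound 2

This account rests on a few compounds, and the source may have more. Where it says the series, first, only, none or still open, it means among the compounds named here.

In a physicochemical assay, read by spectrophotometry, with a stated time of 30 min (on this read-out lower numbers stand for stronger inhibition and higher numbers for weaker inhibition), compound 1 (`O=C(CCc1nc2ccccc2c(=O)[nH]1)N/N=C/c1ccc(O)c(O)c1`) gives 113000000 nM and compound 2 (`O=C(CCc1nc2ccccc2c(=O)[nH]1)N/N=C/c1cc(O)c(O)c(O)c1`) gives 81000000 nM and the two numbers stand within the scatter of each other. Compound 3 (`COc1cc(/C=N/NC(=O)CCc2nc3ccccc3c(=O)[nH]2)cc(O)c1O`) differs from compound 2 by methyl in place of hydrogen on an oxygen on an aromatic ring with methyl in place of hydrogen on an oxygen on an aromatic ring. Among the compounds with values here, the only measured step that bears on this change is hydroxy in place of hydrogen on an aromatic carbon (a 1.4-fold lower number from compound 1 to compound 2 (0.14 log units; within the scatter)) and it is small. No step beyond the scatter is therefore expected in this assay and the estimated step is a 1.2-fold higher number from compound 2 to compound 3 (0.09 log units; within the scatter) at most a working figure. The expected value for compound 3 is 100000000 nM (range 55000000 nM to 190000000 nM).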

Compound 3, half-maximal inhibitory concentration: 104000000 nM
Compound 3: middle estimate off by 1.0-fold (0.02 log units), on the low side; measured number inside the range.
By their numbers in this assay, from the lowest: compounds 2, 3 and 1 (each within the scatter of the next).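

In this assay the oxygen on the aromatic ring carries methyl as well as hydrogen without a step beyond the scatter: hydroxy to methoxy gives a 1.3-fold higher number from compound 2 to compound 3 (0.11 log units; within the scatter). The other new step gives a 1.1-fold lower number from compound 1 to compound 3 (0.04 log units; within the scatter) and is also within the scatter, so neither change at this position separates the three compounds. No supporting measurement accounts for this result.

Still open, going by these compounds, is whether a longer chain on this oxygen, or an amine in place of the hydroxy, would give a step beyond the scatter.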